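Shortening the urea chain toward the bare amide

The compounds below may be only part of what the source reports. "The series", "measured", "known", "first", "only" and "open" are said of these compounds alone.

Three small cyanoaziridine ureas share one core. Compound 1 `CCCCNC(=O)N1CC1C#N` gives 12000 nM in a functional assay on L1210 cells (Mus musculus) for inhibition, read by MTT assay; a higher number here means a weaker inhibitor, a lower number a stronger inhibitor. Compound 2 `N#CC1CN1C(N)=O` reaches only a limit of the assay, > 90000 nM. Compound 3 `CCNC(=O)N1CC1C#N` gives 14000 nM, sitting alongside compound 1. Compound 4 `CNC(=O)N1CC1C#N` is not yet measured; it differs from compound 3 by hydrogen in place of methyl on a saturated chain carbon bound to an amide-type nitrogen. Within the data shown here, two measured steps bear on this. Trimming the chain gave a 1.2-fold higher number from compound 1 to compound 3 (0.07 log units; within the scatter), while removing it entirely gave an at least 7.5-fold higher number from compound 1 to compound 2 (0.87 log units; beyond the scatter) and an at least 6.4-fold lower number from compound 2 to compound 3 (0.80 log units; beyond the scatter), both reaching (the limit of > 90000 nM in this assay, at which 1 of the 3 values shown sits). Because the large loss appears only in an at least 7.5-fold higher number from compound 1 to compound 2 (0.87 log units; beyond the scatter) and not in a 1.2-fold higher number from compound 1 to compound 3 (0.07 log units; within the scatter), compound 4 is expected to change by about a 1.4-fold higher number from compound 3 to compound 4 (0.15 log units; within the scatter). Compound 4 is estimated at 20000 nM, with a range from 8000 nM to 60000 nM.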

Compound 4, half-maximal inhibitory concentration: 8700 nM
Compound 4: the middle estimate sits 2.3-fold (0.36 log units) above what was measured; the range from low to high includes it.
By their numbers in this assay, from the lowest: compounds 4, 1 and 3 (each within the scatter of the next). At a limit, above all of these: compound 2.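

Methyl does as well on this amide-type nitrogen as the longer chains do in this assay (a 1.6-fold lower number from compound 3 to compound 4 (0.21 log units; within the scatter); a 1.4-fold lower number from compound 1 to compound 4 (0.14 log units; within the scatter)), so butyl, ethyl and methyl cannot be told apart here. The methyl group alone is enough to separate compound 4 from the bare amide (an at least 10-fold lower number from compound 2 to compound 4 (1.01 log units; beyond the scatter)). That step gives only a minimum size: the limit of > 90000 nM in this assay, at which 1 of the 4 values shown sits.

Still open, as far as these compounds go, is how a chain longer than butyl, a branched isopropyl group or a phenyl ring would fare here. From the compounds shown here alone, a chain ending in an amine or a carboxylic acid is equally open.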